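Thiophen-3-yl for iodo on the shared nucleoside core

The source may report more compounds than this note shows. Statements on the series, on what has been measured and on what is new or still open speak of the compounds shown alone.

Measured so far:
- compound 1 `COc1nc(N)nc2c1c(-c1cc3ccccc3o1)cn2[C@@H]1O[C@H](CO)[C@@H](O)[C@H]1O`: 14600 nM
- compound 2 `COc1ncnc2c1c(I)cn2[C@@H]1O[C@H](CO)[C@@H](O)[C@H]1O`: > 20000 nM
- compound 3 `Nc1nc2c(c(-c3ccccc3)cn2[C@@H]2O[C@H](CO)[C@@H](O)[C@H]2O)c(=O)[nH]1`: > 20000 nM

Compound 2 `COc1ncnc2c1c(I)cn2[C@@H]1O[C@H](CO)[C@@H](O)[C@H]1O` gives no number in a functional assay on K562 cells (Homo sapiens), read by MTT assay, with a stated time of 72 h; on this read-out higher numbers stand for weaker inhibition and lower numbers for stronger inhibition; its value > 20000 nM is a limit of the assay. Compound 3 likewise sits at a limit, > 20000 nM. Only compound 1 yields a number, 14600 nM, and that too is a weak inhibition. Going by the values given here, compound 2 therefore stands at the limit of > 20000 nM in this assay, at which 2 of the 3 values shown sit, with nothing to separate it from compound 3 and no measured step to lean on.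

Compound 4 `COc1ncnc2c1c(-c1ccsc1)cn2[C@@H]1O[C@H](CO)[C@@H](O)[C@H]1O` is not yet measured. It differs from compound 2 as thiophen-3-yl in place of iodo on an aromatic carbon. Among the compounds with values here, no step between measured compounds involves a change of this kind, so the size of the step in this assay is unknown. Given that compound 2 rests at the limit of > 20000 nM in this assay, at which 2 of the 3 values shown sit, and the closest numbered neighbour, compound 1, shows 14600 nM, compound 4 is expected to remain weak, with a step of an at least 1.6-fold lower number from compound 2 to compound 4 (0.22 log units; that floor lies within the scatter) that may not clear the scatter. The estimate for compound 4 is 12000 nM, between 4000 nM and 20000 nM, with a fair chance that only a limit is reported again.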

Compound 4, half-maximal inhibitory concentration: 90 nM
For compound 4 the middle estimate is 130-fold (2.12 log units) above the measured one, and the stated range ends above it.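

Compound 2 gives > 20000 nM in this assay, which is a limit of the assay and not a number. Thiophen-3-yl in place of iodo on this aromatic carbon gives an at least 220-fold lower number from compound 2 to compound 4 (2.34 log units; beyond the scatter), so on this core the substituent at this position can govern the read-out, something compounds 1 and 3 could not show, as each differs from compound 4 in more than one place. The step is a bound and its true size stays unknown: the limit of > 20000 nM in this assay, at which 2 of the 4 values shown sit.

Going by these compounds, only one replacement for iodo can be read on this core, so it remains open whether the thiophen-3-yl ring itself or its sulfur carries the gain. On these data alone, whether furan-3-yl, an amine or a carboxylic acid at this carbon would keep the number as low is also open.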